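Moving two methoxy groups on a dimethoxyphenyl ring

The source may report more compounds than this note shows. Statements on the series, on what has been measured and on what is new or still open speak of the compounds shown alone.

Compound 1 `COc1ccc(OC)c(C2=C(c3cc(OC)c(OC)c(OC)c3)C(=O)CC2O[SiH2]C(C)(C)C)c1`: 10 ug/mL
Compound 2 `COc1ccc(C2=C(c3cc(OC)c(OC)c(OC)c3)C(=O)C(O)C2)cc1NC(=O)c1ccccc1`: > 100 ug/mL (a limit)
Compound 3 `COc1ccc(C2=C(c3cc(OC)c(OC)c(OC)c3)CC(O)C2=O)cc1[N+](=O)[O-]`: > 100 ug/mL (a limit)

Within the data shown here, in an ADME assay on KB cells (Homo sapiens) for cytotoxicity, read by MTT assay, with a stated time of 72 h (on this read-out higher numbers stand for weaker inhibition and lower numbers for stronger inhibition), compound 1 gives 10 ug/mL, the only actual number among the three compounds. Compound 2 is reported only as a limit of the assay, > 100 ug/mL. Compound 3 is likewise reported only as a limit, > 100 ug/mL. Among the measured compounds shown here, compound 1 therefore stands alone as the one compound with a measured value.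

The next compound, compound 4 `COc1ccc(C2=C(c3cc(OC)c(OC)c(OC)c3)C(=O)CC2O[SiH2]C(C)(C)C)cc1OC`, has not yet been measured. It has the same atoms as compound 1, joined differently: 3,4-dimethoxyphenyl in place of 2,5-dimethoxyphenyl on a double-bonded ring carbon. In words, 3,4-dimethoxyphenyl stands in place of 2,5-dimethoxyphenyl on a double-bonded ring carbon.

For the measured compounds named here, no two measured compounds differ in one place only, so the data offer no measured step for this change. In this assay no step beyond the scatter is therefore expected, in either direction, and the expectation stays anchored on compound 1 at 10 ug/mL. The estimated step is no change at the digits printed from compound 1 to compound 4 (within the scatter). The uncertainty remains wide, as a single number supports it. For compound 4 the expected value is 10 ug/mL, with an estimated range of 3 ug/mL to 50 ug/mL.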

Compound 4, half-maximal inhibitory concentration: > 100 ug/mL
Compound 4 gave a limit, no number; the forecaster's own chance of this, stated with the estimate: 15%; middle value at least 10-fold (1.00 log units) from the limit.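

In this assay, among these compounds, putting 3,4-dimethoxyphenyl in place of 2,5-dimethoxyphenyl on a double-bonded ring carbon gives an at least 10-fold higher number from compound 1 to compound 4 (1.00 log units; beyond the scatter), the first measured step in this set. The two groups have the same atoms and the same counts under the comparison, so this step shows that the read-out at this place depends on how the two methoxy groups are arranged on the phenyl ring, and not only on which atoms are present. As far as these compounds go, compound 4 is reported only as a limit, > 100 ug/mL, so the full size of the step stays unknown, and the result can be read only against the ceiling shared by most of the set: the limit of > 100 ug/mL in this assay, at which 3 of the 4 values shown sit.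

The compounds shown leave open which of the two methoxy positions on the 2,5-dimethoxyphenyl group carries the difference, since no compound with a single methoxy group on this ring stands among them. From the compounds shown here alone, it also remains open whether a fluorine or an amine on the phenyl ring at this place, on the otherwise unchanged core of compound 1, would stay near the value of compound 1 or reach the same limit.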